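A few compounds are considered here, and "the series" means these few. Any claim that something is new, unique, unknown or untested is made for them only; others in the source may bear on it.

Compound 1 `Oc1cc(C(F)(F)F)ccc1-c1nc(-c2ccccc2O)n(-c2ccc(F)cc2)n1` belongs to a set of three measured compounds that share one core and differ only in the group on an aromatic nitrogen of a five-membered aromatic ring with 3 nitrogen. In a functional assay on PC-12 cells (Rattus norvegicus) for cytotoxicity, read by MTT assay, with stated times of 2 h and 24 h, tested at 1 uM (on this read-out higher numbers stand for a stronger effect at the one concentration tested and lower numbers for a weaker effect), compound 1 gives 67.2%, the second highest of the three numbers. Compound 2 `COc1ccc(-n2nc(-c3ccc(C(F)(F)F)cc3O)nc2-c2ccccc2O)cc1` gives 69% in this assay, and compound 3 `N#Cc1ccc(-n2nc(-c3ccc(C(F)(F)F)cc3O)nc2-c2ccccc2O)cc1` gives 66.6%. Methoxy in place of fluoro gave a number 1.8 percentage points higher from compound 1 to compound 2 (within the scatter), cyano in place of fluoro gave a number 0.6 percentage points lower from compound 1 to compound 3 (within the scatter), and cyano in place of methoxy gave a number 2.4 percentage points lower from compound 2 to compound 3 (within the scatter). Compound 4 `COc1cccc(-n2nc(-c3ccc(C(F)(F)F)cc3O)nc2-c2ccccc2O)c1` has not yet been measured in this assay; it differs from compound 1 by 3-methoxyphenyl in place of 4-fluorophenyl on an aromatic nitrogen. All three measured steps exchange the group on that same aromatic nitrogen, and none moved the read-out beyond the scatter. Among the measured compounds shown here, no measured step for a 3-methoxyphenyl exists, so the expectation rests on these three steps. The step of a number 0.8 percentage points higher from compound 1 to compound 4 (within the scatter) is expected to stay within the scatter. For compound 4 the estimate is 68%, with a range from 60% to 76%.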

Compound 4, a percentage reported as activity, at one concentration (the size of the read-out at that concentration, not a potency): 68.3%
For compound 4 the middle estimate is 0.3 percentage points below the measured one; the measured number falls inside the stated range.
By their numbers in this assay, from the lowest: compounds 3, 1, 4 and 2 (each within the scatter of the next).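

Among the compounds shown here, until compound 4, the only groups on this aromatic nitrogen were 4-fluorophenyl, 4-methoxyphenyl and 4-cyanophenyl. In this assay, 3-methoxyphenyl in place of 4-methoxyphenyl gives a number 0.7 percentage points lower from compound 2 to compound 4 (within the scatter), so this read-out does not separate the two methoxyphenyl groups. The other exchanges agree, with 3-methoxyphenyl in place of 4-fluorophenyl giving a number 1.1 percentage points higher from compound 1 to compound 4 (within the scatter) and 3-methoxyphenyl in place of 4-cyanophenyl giving a number 1.7 percentage points higher from compound 3 to compound 4 (within the scatter), and nothing available offers a reason for this flat picture.

On these data alone, all four compounds carry a substituted phenyl group at this position, so it remains open whether an amine or a carboxylic acid on that phenyl, or a longer alkyl chain in its place, would move the read-out beyond the scatter. The compounds also leave open whether changes elsewhere on the shared core would do so.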